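Swapping a fluorophenyl for a methoxyphenyl on the shared core

The compounds below may be only part of what the source reports. "The series", "measured", "known", "first", "only" and "open" are said of these compounds alone.

Measured so far:
compound 1 `c1ccc(-c2cn3ccnc3c(-c3ccc4ncn(C5CCCCC5)c4c3)n2)cc1` gives 37.8%
compound 2 `O=Cc1ccc(-c2cn3ccnc3c(-c3ccc4ncn(C5CCCCC5)c4c3)n2)cc1` gives 37.8%
compound 3 `Fc1ccc(-c2cn3ccnc3c(-c3ccc4ncn(C5CCCCC5)c4c3)n2)cc1` gives 6.12%

In a functional assay on NCI-H460 cells (Homo sapiens) for inhibition, read by sulforhodamine B assay, with a stated time of 48 h, tested at 10 uM (a lower number here means less inhibition, a higher number more inhibition at the concentration tested (going by the name of the read-out)), compound 3 stands lowest of the three, well apart from both others. Compound 4 `COc1ccccc1-c1cn2ccnc2c(-c2ccc3ncn(C4CCCCC4)c3c2)n1` is not yet measured; it differs from compound 3 in one place: 2-methoxyphenyl in place of 4-fluorophenyl on an aromatic carbon. Among the compounds with values here, two measured steps bear on this. Adding fluoro gave a number 31.7 percentage points lower from compound 1 to compound 3 (beyond the scatter), and swapping formyl for fluoro gave a number 31.7 percentage points lower from compound 2 to compound 3 (beyond the scatter). Both suggest that removing the fluoro should raise inhibition again. Nothing measured here tells what 2-methoxyphenyl itself does, so the expectation is wide. Compound 4 is therefore expected to give about 33%, within roughly 5% to 60%, an expected step of a number 26.9 percentage points higher from compound 3 to compound 4 (beyond the scatter).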

Compound 4, a percentage reported as inhibition, at one concentration (the size of the read-out at that concentration, not a potency): 9.62%
The estimate for compound 4 lay 23.4 percentage points above the measured number; the measured number falls inside the stated range.
By their numbers in this assay, from the lowest: compounds 3 and 4 (each within the scatter of the next); then compounds 1 and 2 (each within the scatter of the next).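

In this assay, 2-methoxyphenyl in place of 4-fluorophenyl gives a number 3.5 percentage points higher from compound 3 to compound 4 (within the scatter), so two different substituted phenyl groups at this position read alike. Methoxy in place of hydrogen gives a number 28.2 percentage points lower from compound 1 to compound 4 (beyond the scatter), and 2-methoxyphenyl in place of 4-formylphenyl gives a number 28.2 percentage points lower from compound 2 to compound 4 (beyond the scatter), so the low reading is not unique to fluoro, although formyl shows that not every substituent lowers it. On these data alone, whether an amine or a carboxylic acid on this phenyl ring would keep or lower the inhibition stays open. Nothing measured here explains why these groups differ.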